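The source may report more compounds than this note shows. Statements on the series, on what has been measured and on what is new or still open speak of the compounds shown alone.

Compound 1 `COc1cc2cc(Oc3ccc(NC(=O)Nc4cccc(C(F)(F)F)c4)cc3)c(C)nc2cc1OC` gives 1980 nM in a functional assay on UO-31 cells (Homo sapiens) for inhibition, read by sulforhodamine B assay, with a stated time of 48 h; a higher number here means a weaker inhibitor of growth, a lower number a stronger inhibitor of growth. Compound 2 `COc1cc2cc(Oc3ccc(NC(=O)Nc4ccc(Cl)c(C(F)(F)F)c4)cc3)c(C)nc2cc1OC` gives 924 nM in this assay.

Among the compounds with values here, of these two numbers, compound 2 holds the lower one; the only measured step is a 2.1-fold lower number from compound 1 to compound 2 (0.33 log units; beyond the scatter). Compound 3 `COc1cc2cc(Oc3ccc(NC(=O)Nc4ccc(Cl)c(Cl)c4)cc3)c(C)nc2cc1OC` differs from compound 2 by chloro in place of trifluoromethyl on an aromatic carbon. Within the data shown here, no measured step swaps trifluoromethyl for chloro, so the step from compound 1 to compound 2, which adds a chloro where hydrogen stood, does not speak to it directly. Compound 3 is therefore expected close to compound 2, the expected step being a 1.4-fold higher number from compound 2 to compound 3 (0.15 log units; within the scatter). Compound 3 is estimated at 1300 nM, between 500 nM and 3500 nM.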

Compound 3, concentration for 50% growth inhibition: 3440 nM
For compound 3 the middle estimate is 2.6-fold (0.42 log units) below the measured one, and the stated range covers the measured number.
By their numbers in this assay, from the lowest: compound 2; then compounds 1 and 3 (each within the scatter of the next).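

With a chloro group ortho to this position, trifluoromethyl cannot be exchanged for chloro without loss: the change gives a 3.7-fold higher number from compound 2 to compound 3 (0.57 log units; beyond the scatter). The advantage of compound 2 is therefore absent from compound 3, whose number stands close to that of compound 1, with a 1.7-fold higher number from compound 1 to compound 3 (0.24 log units; within the scatter). Nothing shown explains why these two groups differ here.

Still open, as far as these compounds go, is how a methyl, a methoxy or a nitrile would behave at this position. From the compounds shown here alone, whether any of them would match trifluoromethyl remains unknown.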